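The compounds below may be only part of what the source reports. "The series", "measured", "known", "first", "only" and "open" are said of these compounds alone.

The series shares the core of compound 1 `CCc1cccc2c(OC)c(-c3occ(C)c3C(=O)OC)ccc12`, which carries a methyl ester on the five-membered ring. In a functional assay on DU-145 cells (Homo sapiens) for cytotoxicity, read by MTT assay, with a stated time of 72 h (on this read-out lower numbers stand for an effect already at smaller amounts and higher numbers for an effect only at larger amounts of compound), compound 1 gives 2.2 ug/mL. Compound 2 `CCc1cccc2c(OC)c(-c3occ(C)c3C(=O)NC)ccc12` carries a methylamide in its place. In this assay compound 2 sits at > 10 ug/mL, which is a limit of the assay and not a number. Compound 3 `CCc1cccc2c(OC)c(-c3occ(C)c3C(=O)On3nnc4ccccc43)ccc12` carries a larger ester. In this assay compound 3 likewise sits at > 10 ug/mL, again a limit. Both changes away from the methyl ester run the same way: an at least 4.5-fold higher number from compound 1 to compound 2 (0.65 log units; beyond the scatter) and an at least 4.5-fold higher number from compound 1 to compound 3 (0.65 log units; beyond the scatter). The step that the two limits leave unreadable from compound 2 to compound 3 is not readable because of the limit of > 10 ug/mL in this assay, at which 2 of the 3 values shown sit.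

Compound 4 `CCc1cccc2c(OC)c(-c3occ(C)c3CBr)ccc12` differs from compound 2 by bromomethyl in place of methylcarbamoyl on an aromatic carbon. Within the data shown here, no measured step in this set covers a change of this kind; the two steps that are readable start from the methyl ester of compound 1 and end at the limit. Compound 2 itself stands only at a limit, so the starting point for compound 4 is not a number either. For compound 4 the number in this assay is therefore estimated only loosely, at 5 ug/mL, within 1 ug/mL to 20 ug/mL. This estimate would mean a step of an at least 2.0-fold lower number from compound 2 to compound 4 (0.30 log units; that floor lies within the scatter), with a real chance that compound 4 also returns only a limit.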

Compound 4, concentration for half-maximal effect: > 10 ug/mL
Compound 4 was reported as a limit (the forecaster's own chance of this, stated with the estimate: 35%); middle value at least 2.0-fold (0.30 log units) from the limit.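

Among these compounds, compound 4 is the first change at this position that removes the carbonyl altogether, and with bromomethyl in place of methoxycarbonyl the result is an at least 4.5-fold higher number from compound 1 to compound 4 (0.65 log units; beyond the scatter). In this assay compound 4 stands at > 10 ug/mL, which is a limit of the assay and not a number. The methyl ester of compound 1 thus remains the only group at this aromatic carbon with a readable value, while the methylamide, the larger ester and the carbonyl-free bromomethyl group all end at the limit, and the steps from compound 2 to compound 3 and from compound 2 to compound 4 cannot be read: the limit of > 10 ug/mL in this assay, at which 3 of the 4 values shown sit.

How far compound 2, compound 3 and compound 4 lie from one another remains open, so no order among these three groups can be given. Also open, going by these compounds, is whether an ethyl ester, a carboxylic acid or a hydroxymethyl group on the same aromatic carbon would give a number in this assay, and how such a number would compare with that of compound 1.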